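The source may report more compounds than this note shows. Statements on the series, on what has been measured and on what is new or still open speak of the compounds shown alone.

Of the compounds shown here, two have been measured in an assay for inhibition of kynurenine 3-monooxygenase (Homo sapiens), read by mass spectrometry, with a stated time of 1 h; a lower number here means a stronger inhibitor, a higher number a weaker inhibitor. Compound 1 `Cc1ccc([C@@H](C)Oc2cc3oc(=O)n(CCC(=O)O)c3cc2Cl)nc1` gives 3.16 nM in this assay. Compound 2 `COc1cc2oc(=O)n(CCC(=O)O)c2cc1Cl`, which carries only a methyl on the ether oxygen, gives 12.6 nM in this assay, the higher of the two numbers; the gap to compound 1 lies beyond the usual scatter, so compound 2 is the weaker inhibitor of the pair.

Compound 3 `C[C@@H](Oc1cc2oc(=O)n(CCC(=O)O)c2cc1Cl)c1ncccn1` has not yet been measured. Compared with compound 2 it differs in this way: a group of 8 heavy atoms (6 carbon, 2 nitrogen; one six-membered aromatic ring with 2 hetero atoms) in place of one carbon atom, on an oxygen on an aromatic ring. The change thus replaces the small methyl ether of compound 2 with a larger substituted ethyl ether of the kind that compound 1 also carries, though with a different six-membered aromatic ring.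

For the measured compounds named here, no step with exactly this pair is on record, so the expectation rests on the two measured values. Because compound 1 reaches 3.16 nM with a related ether, compound 3 is expected to land closer to compound 1 than to compound 2, a step toward a stronger inhibitor of moderate size. The estimate implies an expected step of a 2.8-fold lower number from compound 2 to compound 3 (0.45 log units; beyond the scatter) in this assay. In this assay compound 3 is therefore estimated at 4.5 nM, with a likely range from 1.5 nM to 14 nM.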

Compound 3, half-maximal inhibitory concentration: 5.01 nM
Beside the measured number, compound 3's estimate is 1.1-fold (0.05 log units) below it; the measured number falls inside the stated range.
By their numbers in this assay, from the lowest: compounds 1 and 3 (each within the scatter of the next); then compound 2.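

In this assay, putting the larger group bearing a pyrimidin-2-yl ring on the oxygen in place of the methyl gives a 2.5-fold lower number from compound 2 to compound 3 (0.40 log units; beyond the scatter), which shows that this position accepts a second aromatic ring type on the saturated chain carbon while staying ahead of the methyl ether. The direct exchange of 5-methylpyridin-2-yl for pyrimidin-2-yl gives a 1.6-fold higher number from compound 1 to compound 3 (0.20 log units; within the scatter), so this assay does not separate the two rings, and the extra ring nitrogen and the loss of the ring methyl together leave the number within the scatter. No measurement shown here accounts for either step.

The compounds shown leave open whether a ring nitrogen matters at all, as a phenyl ring on the same saturated chain carbon would test, and whether the ring itself is needed, as a plain ethyl on the oxygen would test. They also leave open what the opposite configuration at the defined stereocentre would give, and whether the methyl on that saturated chain carbon contributes to the step from the methyl ether.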